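Swapping the aryl group on sulfur: from dichloro to fluoro

The compounds below may be only part of what the source reports. "The series", "measured", "known", "first", "only" and "open" are said of these compounds alone.

Compound 1 `Nc1cc(N)c2nc(-c3ccccc3)c(Oc3ccc(Cl)c(Cl)c3)nc2c1`: 5010 nM
Compound 2 `COc1ccc(Sc2nc3cc(N)cc(N)c3nc2-c2ccccc2)cc1`: < 100000 nM
Compound 3 `Nc1cc(N)c2nc(-c3ccccc3)c(Sc3ccc(Cl)c(Cl)c3)nc2c1`: 18200 nM

Of the compounds shown here, three sharing one core have been tested in a functional assay on MDA-MB-435 cells (Homo sapiens) for inhibition, read by sulforhodamine B assay, with a stated time of 48 h; on this read-out higher numbers stand for weaker inhibition of growth and lower numbers for stronger inhibition of growth. Compound 1 gives 5010 nM. For compound 2 only a limit of the assay is reported, < 100000 nM, so no number is known there. Compound 3 gives 18200 nM, the highest of the two numbers available; the step of a 3.6-fold higher number from compound 1 to compound 3 (0.56 log units; beyond the scatter) is the only readable one, and it is modest. The step that the limit leaves unreadable from compound 2 to compound 3 cannot be sized, because compound 2 sits at the limit of < 100000 nM in this assay, at which 1 of the 3 values shown sits.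

Compound 4 `Nc1cc(N)c2nc(-c3ccccc3)c(Sc3ccc(F)cc3)nc2c1` is not yet measured. It differs from compound 3 by 4-fluorophenyl in place of 3,4-dichlorophenyl on a sulfur. Among the compounds with values here, the closest precedent is the change from compound 2 to compound 3, which also swaps the aryl group on sulfur, yet it remains unreadable, so no measured step tells how large a change to expect. With only a limit for compound 2 and a modest number for compound 3, the expectation for compound 4 is a somewhat higher number than compound 3, with wide uncertainty. The expected step of a 1.6-fold higher number from compound 3 to compound 4 (0.22 log units; within the scatter) is therefore weakly upward, and compound 4 is estimated at 30000 nM, within 8000 nM to 100000 nM.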

Compound 4, concentration for 50% growth inhibition: 16200 nM
Compound 4: middle estimate off by 1.9-fold (0.27 log units), on the high side; the range from low to high includes it.
By their numbers in this assay, from the lowest: compound 1; then compounds 4 and 3 (each within the scatter of the next).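

Within the data shown here, on the aryl group on sulfur, the swap to 4-fluorophenyl in place of 3,4-dichlorophenyl gives the first readable change at this place in this assay: a 1.1-fold lower number from compound 3 to compound 4 (0.05 log units; within the scatter), so these two aryl groups cannot be told apart here. The gap to compound 1, which carries 3,4-dichlorophenoxy, also persists with the new aryl group, as a 3.2-fold higher number from compound 1 to compound 4 (0.51 log units; beyond the scatter) stands close to the earlier 3.6-fold higher number from compound 1 to compound 3 (0.56 log units; beyond the scatter), so this gap does not depend on which of these two aryl groups sits on the sulfur. Compound 2 has only a limit, so the step from it to compound 4 cannot be read: the limit of < 100000 nM in this assay, at which 1 of the 4 values shown sits.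

The compounds shown leave open whether a 4-fluorophenoxy group on the shared core would keep the number of compound 1 or move it toward that of compound 4, which would separate the role of the linking atom from that of the ring. They also leave open how an amine or a carboxylic acid on the aryl ring, or a longer chain on the sulfur in place of the ring, would change growth inhibition.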